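The source may hold more compounds than are shown below. What is called first, only, known or untested is meant among the compounds shown, and "the series" means these compounds.

Of the compounds shown here, three of one series have been tested in a functional assay on MCF7 cells (Homo sapiens) for inhibition, read by MTT assay, with a stated time of 48 h, tested at 10 uM; a lower number here means less inhibition, a higher number more inhibition at the concentration tested (going by the name of the read-out). Compound 1 `COc1cc2ccc(=O)oc2cc1OCCOc1no[n+]([O-])c1S(=O)(=O)c1ccccc1` gives 89.2% in this assay, and compound 2 `COc1cc2ccc(=O)oc2cc1OCCCOc1no[n+]([O-])c1S(=O)(=O)c1ccccc1`, which carries a longer linker chain, gives 88.6%. Compound 3 `COc1cc2cc(NC(C)=O)c(=O)oc2cc1OCCOc1no[n+]([O-])c1S(=O)(=O)c1ccccc1` gives 83.7% in this assay. Compound 3 sits at the low end of the three numbers, but its gap to compound 2 and its gap to compound 1 both lie within the usual scatter, so the three cannot be told apart. Going by the values given here, the only single-point step among the measured compounds is a number 5.5 percentage points lower from compound 1 to compound 3 (within the scatter), which brings an acetamido group onto an aromatic carbon and leaves the read-out essentially unchanged.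

Compound 4 `COc1cc2cc(N)c(=O)oc2cc1OCCOc1no[n+]([O-])c1S(=O)(=O)c1ccccc1` is the next compound and differs from compound 3 in one place: hydrogen in place of acetyl on a nitrogen on an aromatic ring. Among the compounds with values here, no measured pair shows this exact change. Within the data shown here, the one step that touches the same part of the core, the acetamido for hydrogen step from compound 1 to compound 3, was within the scatter, and all three measured numbers lie close together. Compound 4 is therefore expected to show no step beyond the scatter, with a number 1.3 percentage points higher from compound 3 to compound 4 (within the scatter) as the estimated change. For compound 4 the expected value in this assay is 85%, with a likely range from 74% to 93%.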

Compound 4, a percentage reported as inhibition, at one concentration (the size of the read-out at that concentration, not a potency): 88.6%
The estimate for compound 4 lay 3.6 percentage points below the measured number, and the stated range covers the measured number.
By their numbers in this assay, from the lowest: compounds 3, 2, 4 and 1 (each within the scatter of the next).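

In this assay, taking the acetyl off the nitrogen on the aromatic ring gives a number 4.9 percentage points higher from compound 3 to compound 4 (within the scatter), and the amino group set against hydrogen on the aromatic carbon gives a number 0.6 percentage points lower from compound 1 to compound 4 (within the scatter). The same aromatic carbon has now carried hydrogen, acetamido and amino on an otherwise shared core, and with the free amino group added to the comparison, this read-out at one concentration still does not separate any of the three. The compounds therefore show that neither the acetyl nor the amino group, as tested here, makes a difference beyond the scatter, and no supporting data bear on why the read-out holds steady across these changes.

From the compounds shown here alone, whether a dimethylamino group, a carboxylic acid or a chlorine atom on that aromatic carbon would produce a step beyond the scatter remains open. Also open, going by these compounds, is whether the amino group would behave the same way on the longer linker chain of compound 2, and whether compound 1, compound 3 and compound 4 would show a stronger or weaker effect at other concentrations, which a single concentration cannot show.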